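The source may report more compounds than this note shows. Statements on the series, on what has been measured and on what is new or still open speak of the compounds shown alone.

In a functional assay on Bel7402/5-FU cells (Homo sapiens) for cytotoxicity, read by MTT assay, with a stated time of 72 h (a higher number here means a weaker inhibitor, a lower number a stronger inhibitor), compound 1 `O=C1C=CCC/C1=C\C=C\c1ccccc1` gives 4200 nM and compound 2 `Cc1ccc(/C=C/C=C2\CCC=CC2=O)cc1` gives 5800 nM as its value. Among the measured compounds shown here, the only measured step of a 1.4-fold higher number from compound 1 to compound 2 (0.14 log units; within the scatter) is methyl in place of hydrogen on an aromatic carbon. Compound 2 therefore stands level with compound 1 within the scatter, and these two are the only measured points. For the measured compounds named here, compound 3 `O=C1C=CCC/C1=C\C=C\c1ccc(Cl)cc1` has chloro in place of methyl on an aromatic carbon as its one change from compound 2. Going by the values given here, no measured compound carries chloro, so the single step from compound 1 is the only guide, and that step a 1.4-fold higher number from compound 1 to compound 2 (0.14 log units; within the scatter) stayed within the scatter. No step beyond the scatter is therefore expected in this assay for this exchange. The expected step is a 1.3-fold lower number from compound 2 to compound 3 (0.11 log units; within the scatter) as an estimate. For compound 3 the estimated value is 4500 nM with an expected range from 1800 nM to 10000 nM around it.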

Compound 3, half-maximal inhibitory concentration: 3200 nM
The estimate for compound 3 lay 1.4-fold (0.15 log units) above the measured number, within the range that was stated.
By their numbers in this assay, from the lowest: compounds 3, 1 and 2 (each within the scatter of the next).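

In this assay, the aromatic carbon para to a large group now carries a second kind of substituent, and neither a 1.8-fold lower number from compound 2 to compound 3 (0.26 log units; within the scatter) nor a 1.3-fold lower number from compound 1 to compound 3 (0.12 log units; within the scatter) leaves the scatter. Earlier, only the exchange of hydrogen for methyl had been seen at this place; now hydrogen, methyl and chloro all stand level within the scatter on the shared core, so this assay does not separate these three groups at this position. Nothing available explains this flat result.

The compounds shown leave open whether an amine, a carboxylic acid or a longer chain at this place would give a step beyond the scatter. They also leave open whether chloro on another carbon of the aromatic ring would stay within the scatter as it does here.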